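The compounds below may be only part of what the source reports. "The series", "measured", "known", "first", "only" and "open" are said of these compounds alone.

In an ADME assay on MT4 cells (Homo sapiens) for cytotoxicity, read by MTT assay, with a stated time of 4 days (on this read-out lower numbers stand for higher toxicity in this test and higher numbers for lower toxicity in this test), compound 3 `COc1ccccc1Oc1nc(Nc2ccc(C#N)cc2)nc2ccccc12` gives 150000 nM, the highest of the two numbers measured. Compound 1 `N#Cc1ccc(Nc2nc(Oc3c(Br)cc(Br)cc3Br)c3ccccc3n2)cc1` gives 58000 nM in this assay, and the step of a 2.6-fold higher number from compound 1 to compound 3 (0.41 log units; beyond the scatter) is the only one that can be read. For compound 2 `Cc1cc(C)c(Oc2nc(Nc3ccc(C#N)cc3)nc3ccccc23)c(C)c1` this assay gives only a limit, > 34000 nM. Compound 4 `Cc1cc(Br)c(Oc2nc(Nc3ccc(C#N)cc3)nc3ccccc23)c(Br)c1` has not yet been measured; it differs from compound 3 by 2,6-dibromo-4-methylphenyl in place of 2-methoxyphenyl on an oxygen on an aromatic ring. The entering 2,6-dibromo-4-methylphenyl carries bromines like the 2,4,6-tribromophenyl of compound 1, so this change runs opposite to a 2.6-fold higher number from compound 1 to compound 3 (0.41 log units; beyond the scatter), and a modest lower number is expected for compound 4, about a 2.5-fold lower number from compound 3 to compound 4 (0.40 log units; beyond the scatter). Compound 4 is therefore estimated at 60000 nM, with a range from 25000 nM to 150000 nM.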

Compound 4, half-maximal cytotoxic concentration: 25000 nM
Estimate against measurement, compound 4: 2.4-fold (0.38 log units) above, within the range that was stated.
By their numbers in this assay, from the lowest: compound 4; then compound 1; then compound 3.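

Placing bromines on the ring on this oxygen can lower the number far more than compound 1 suggested: the step is a 6.0-fold lower number from compound 3 to compound 4 (0.78 log units; beyond the scatter). The result also shows that the third ring substituent matters, since methyl in place of bromo on an aromatic carbon gives a 2.3-fold lower number from compound 1 to compound 4 (0.37 log units; beyond the scatter), so toxicity in this test does not simply rise with the number of bromines. The step of an at least 1.3-fold lower number from compound 2 to compound 4 (0.13 log units; that floor lies within the scatter) rests on a limit and gives only a floor.

As far as these compounds go, what a ring carrying chloro groups would give in this assay remains open. So does the effect of a morpholine ring in place of the aryl group on this oxygen.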